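Replacing a Methyl with (Chloromethyl)carbonyl on an Oxygen

The source may hold more compounds than are shown below. What is called first, only, known or untested is meant among the compounds shown, and "the series" means these compounds.

In a functional assay on cells (Endothelial cell, Sus scrofa) for antiproliferative activity (a lower number here means a stronger inhibitor, a higher number a weaker inhibitor), compound 1 `CO[C@@H]1[C@H](OC(=O)NC(=O)CCl)CO[C@]2(COC(C)(C)O2)[C@@]1(O)C1(C)CO1` gives 57000 nM, while compound 2 `CO[C@@H]1[C@H](OC(=O)NC(=O)CCl)CO[C@]2(COC(C)(C)O2)[C@@]1(OC)C1(C)CO1` gives 175000 nM, the higher of the two numbers. Compound 3 `CO[C@@H]1[C@H](OC(=O)NC(=O)CCl)CO[C@]2(COC(C)(C)O2)[C@@]1(OC(=O)CCl)C1(C)CO1` has (chloromethyl)carbonyl in place of methyl on an oxygen on a saturated carbon. Among the measured compounds shown here, only one measured step bears on this oxygen, the modest 3.1-fold higher number from compound 1 to compound 2 (0.49 log units; beyond the scatter), where methyl replaced hydrogen. For the measured compounds named here, no measured compound carries the entering group, so the expectation is loose, but losing that methyl may reverse much of the rise. The expected change is a 2.9-fold lower number from compound 2 to compound 3 (0.46 log units; beyond the scatter). Compound 3 is estimated at 60000 nM, within an expected range of 8000 nM to 250000 nM.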

Compound 3, half-maximal inhibitory concentration: 122000 nM
Estimate against measurement, compound 3: 2.0-fold (0.31 log units) below; low and high end bracket the measured number.
By their numbers in this assay, from the lowest: compound 1; then compounds 3 and 2 (each within the scatter of the next).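

In this assay, putting (chloromethyl)carbonyl in place of methyl on this oxygen leaves the number essentially unchanged (a 1.4-fold lower number from compound 2 to compound 3 (0.16 log units; within the scatter)). Set against the free hydroxyl, the same group gives a modest rise (a 2.1-fold higher number from compound 1 to compound 3 (0.33 log units; beyond the scatter)), so on these compounds both groups on the oxygen read weaker than hydrogen, and they cannot be told apart from each other. Nothing at hand accounts for this. The compounds shown leave open whether a plain acetyl, without the chlorine, or a longer chain such as benzyl on this oxygen would read the same way.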